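Pyridin-4-yl in Place of Pyridin-3-yl: An Expected Step

This account rests on a few compounds, and the source may have more. Where it says the series, first, only, none or still open, it means among the compounds named here.

Of the compounds shown here, three have so far been tested in a functional assay on MCF7 cells (Homo sapiens) for inhibition, read by sulforhodamine B assay, with a stated time of 72 h; on this read-out higher numbers stand for weaker inhibition and lower numbers for stronger inhibition. Compound 1 `O=C(/C=C/c1cn(-c2ccccc2)nc1-c1cccnc1)c1ccccc1` gives 4100 nM in this assay. Compound 3 `O=C(/C=C/c1cn(-c2ccccc2)nc1-c1ccncc1)c1ccccc1` shares the core of compound 1 and differs from it in one place, (pyridin-4-yl in place of pyridin-3-yl on an aromatic carbon). In this assay compound 3 gives 3400 nM, and the step of a 1.2-fold lower number from compound 1 to compound 3 (0.08 log units; within the scatter) shows that this change hardly moved the number.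

Compound 2 `COc1cc(OC)c(C(=O)/C=C/c2cn(-c3ccccc3)nc2-c2cccnc2)c(OC)c1` differs from compound 1 in a larger part of the molecule; the difference between the two cores is not broken down here. In this assay compound 2 gives 1000 nM, the lowest of the three numbers, and its gaps to compound 3 and to compound 1 both lie beyond the scatter.

Compound 4 `COc1cc(OC)c(C(=O)/C=C/c2cn(-c3ccccc3)nc2-c2ccncc2)c(OC)c1` has not yet been measured. It differs from compound 2 by pyridin-4-yl in place of pyridin-3-yl on an aromatic carbon. The surroundings of the change are the same word for word as in the step from compound 1 to compound 3, so this is the same change made on the core of compound 2.

Because the step of a 1.2-fold lower number from compound 1 to compound 3 (0.08 log units; within the scatter) lies within the scatter, the same change on compound 2 is expected to leave the number close to where it stands, giving an expected step of a 1.2-fold lower number from compound 2 to compound 4 (0.07 log units; within the scatter). Compound 4 is therefore estimated to give 850 nM in this assay. For compound 4 the expected range runs from 350 nM to 2200 nM, allowing for the usual scatter and for one example being a thin basis.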

Compound 4, half-maximal inhibitory concentration: 1600 nM
Estimate against measurement, compound 4: 1.9-fold (0.27 log units) below; the measured number falls inside the stated range.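

On the core of compound 2, putting pyridin-4-yl in place of pyridin-3-yl gives a 1.6-fold higher number from compound 2 to compound 4 (0.20 log units; within the scatter) in this assay, so the two numbers stay within the usual scatter of each other. Set beside the earlier step, the result on the second core agrees with the first: the same change on two cores in this assay, a 1.2-fold lower number (0.08 log units; within the scatter) from compound 1 to compound 3 and a 1.6-fold higher number (0.20 log units; within the scatter) from compound 2 to compound 4, 1.9-fold (0.29 log units) apart, within the scatter of two such steps This shows that, on these two cores, the swap between the two pyridine groups can be carried from one core to the other without the number moving beyond the scatter, but it does not show that the two steps truly run in opposite directions, that the change has no small real effect, or that the same would hold on any other core in the series.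

Two pairs are a narrow basis, and they leave open whether a pyridin-2-yl group or a plain phenyl group on the same aromatic carbon would fit with the two pyridine groups seen here. They also leave open whether the swap would stay as quiet on a core where an amine or a carboxylic acid replaces the methoxy groups of compound 2 and compound 4.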